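Methyl for fluoro on the amide-side aryl ring

The source may hold more compounds than are shown below. What is called first, only, known or untested is meant among the compounds shown, and "the series" means these compounds.

Compound 1 `O=C(NCc1ccc(CNS(=O)(=O)c2ccccc2)cc1)c1cccc(F)c1` carries a fluoro group on the aromatic ring attached to the carbonyl. In an assay on MDA-MB-231 cells for binding affinity to C-X-C chemokine receptor type 4 (Homo sapiens), read by immunofluorescence and microscopy, with stated times of 10 min and 30 min (on this read-out lower numbers stand for an effect already at smaller amounts and higher numbers for an effect only at larger amounts of compound), compound 1 gives 100 nM, the highest of the three values measured. Compound 2 `COc1cccc(C(=O)NCc2ccc(CNS(=O)(=O)c3ccc(C)cc3)cc2)c1` gives 10 nM, and compound 3 `Cc1ccc(S(=O)(=O)NCc2ccc(CNC(=O)c3ccc(Cl)cc3)cc2)cc1` gives 10 nM; the step of no change at the digits printed from compound 2 to compound 3 (within the scatter) shows that placing 4-chlorophenyl instead of 3-methoxyphenyl on the carbonyl carbon changed nothing beyond the scatter. Compound 4 `Cc1cccc(C(=O)NCc2ccc(CNS(=O)(=O)c3ccccc3)cc2)c1` differs from compound 1 by methyl in place of fluoro on an aromatic carbon. Among the compounds with values here, no measured step exchanges fluoro for methyl, and compounds 2 and 3 also differ from compound 1 on the sulfonyl side, so their lower numbers cannot be tied to the carbonyl-side ring alone. The step from compound 1 to compound 4 is therefore expected to be small, a 1.3-fold lower number from compound 1 to compound 4 (0.10 log units; within the scatter). Compound 4 is estimated at 80 nM, within a range from 25 nM to 250 nM.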

Compound 4, effective concentration (reported as EC, without a stated level of effect): 1000 nM
Beside the measured number, compound 4's estimate is 13-fold (1.10 log units) below it; the whole stated range lies below it.
By their numbers in this assay, from the lowest: compounds 2 and 3 (each within the scatter of the next); then compound 1; then compound 4.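

In this assay, a single heavy atom exchanged on this aromatic carbon, methyl in place of fluoro, gives a 10-fold higher number from compound 1 to compound 4 (1.00 log units; beyond the scatter) and so shows that this position responds to a small change. Within the data shown here, the only earlier step on this ring, no change at the digits printed from compound 2 to compound 3 (within the scatter), gave no sign of such a response. Nothing shown gives a reason for this step.

Going by these compounds, it remains open how an amine or a carboxylic acid on this aromatic carbon would read, and whether the same exchange gives a similar step with the sulfonyl side of compound 2.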